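This account rests on a few compounds, and the source may have more. Where it says the series, first, only, none or still open, it means among the compounds named here.

In a functional assay on HeLa cells (Homo sapiens) for inhibition, read by sulforhodamine B assay (on this read-out lower numbers stand for stronger inhibition and higher numbers for weaker inhibition), compound 3 `O=C1C(NC2CCCC2)=CC(=O)c2c1nc1n2[C@H]2OC[C@@H](O)[C@H]2OC1` gives > 16000 nM as its reading, which is a limit and not a number. On this assay compound 1 `O=C1C(Nc2ccc(I)cc2)=CC(=O)c2c1nc1n2[C@H]2OC[C@@H](O)[C@H]2OC1` reads 4010 nM and compound 2 `O=C1C(Nc2ccccc2F)=CC(=O)c2c1nc1n2[C@H]2OC[C@@H](O)[C@H]2OC1` reads 9820 nM as true numbers.

Compound 4 `O=C1C(Nc2ccc(Br)cc2)=CC(=O)c2c1nc1n2[C@H]2OC[C@@H](O)[C@H]2OC1` differs from compound 3 by 4-bromophenyl in place of cyclopentyl on an amine nitrogen with 4-bromophenyl in place of cyclopentyl on an amine nitrogen.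

The nearest measured step, run in reverse, is an at least 3.9-fold higher number from compound 1 to compound 3 (0.60 log units; beyond the scatter) and it starts from a 4-iodophenyl group. Less firm is an at least 1.6-fold higher number from compound 2 to compound 3 (0.21 log units; that floor lies within the scatter) whose floor stays within the scatter, while a 2.4-fold higher number from compound 1 to compound 2 (0.39 log units; beyond the scatter) shows that the choice of phenyl group can itself shift the number.

A step of at least modest size toward a lower number on this assay is therefore expected, with compound 1 at 4010 nM as the closest guide. The expected step is an at least 3.2-fold lower number from compound 3 to compound 4 (0.50 log units; beyond the scatter) on this estimate. Compound 4 is estimated at 5000 nM with an expected range of 2500 nM to 11000 nM in these notes.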

Compound 4, half-maximal inhibitory concentration: 5220 nM
Beside the measured number, compound 4's estimate is 1.0-fold (0.02 log units) below it, within the range that was stated.
By their numbers in this assay, from the lowest: compounds 1, 4 and 2 (each within the scatter of the next, the first and the last beyond it). At a limit, above all of these: compound 3.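

In this assay, 4-bromophenyl in place of cyclopentyl on the amine nitrogen gives an at least 3.0-fold lower number from compound 3 to compound 4 (0.48 log units; beyond the scatter), so a second phenyl group now stands clear of cyclopentyl, though only as a floor. Compound 3 reads as a limit and not a number: the limit of > 16000 nM in this assay, at which 1 of the 4 values shown sits. Iodo is not needed for this reading, as bromo in its place gives a 1.3-fold higher number from compound 1 to compound 4 (0.11 log units; within the scatter), and the comparison with 2-fluorophenyl, a 1.9-fold lower number from compound 2 to compound 4 (0.27 log units; within the scatter), does not separate those two groups either.

The compounds shown leave open how an unsubstituted phenyl, a 4-chlorophenyl or a 4-methoxyphenyl group would read at this amine nitrogen. Also open, as far as these compounds go, is whether a benzyl group or an open alkyl chain would read nearer to the phenyl compounds or to cyclopentyl.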